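Swapping a hydroxymethylethyl group for a dimethylisoxazole

This account rests on a few compounds, and the source may have more. Where it says the series, first, only, none or still open, it means among the compounds named here.

Measured compounds:
compound 1 `Cc1cc(C)c(CN2CCc3c(Cl)cc([C@H](CO)[C@@H]4CCCO4)c(Cl)c3C2=O)c(=O)[nH]1` — 37.6 uL/min
compound 2 `Cc1cc(C)c(CN2CCc3c(Cl)cc([C@H](C)CO)c(Cl)c3C2=O)c(=O)[nH]1` — 15.8 uL/min

In an ADME assay on microsomes from liver (Homo sapiens) for metabolic stability, read by LC-MS, using NADPH, with stated times of 10 min and 45 min, tested at 1 uM (a higher number here means faster removal of the compound, a lower number slower removal), compound 2 gives the lowest of the two numbers; its nearest neighbour is compound 1, reached by a 2.4-fold lower number from compound 1 to compound 2 (0.38 log units; beyond the scatter). Compound 3 `Cc1cc(C)c(CN2CCc3c(Cl)cc(-c4c(C)noc4C)c(Cl)c3C2=O)c(=O)[nH]1` differs from compound 2 by 3,5-dimethyl-1,2-oxazol-4-yl in place of 1-(hydroxymethyl)ethyl on an aromatic carbon. Within the data shown here, the only measured step, from compound 1 to compound 2, also exchanged a group on that aromatic carbon and was modest, but it bears only loosely on this change. The number for compound 3 is therefore expected to rise moderately, by a 1.6-fold higher number from compound 2 to compound 3 (0.20 log units; within the scatter), with wide uncertainty. Compound 3 is estimated at 25 uL/min, within 10 uL/min to 60 uL/min.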

Compound 3, intrinsic clearance in a liver preparation (reported as CLH), per the amount of preparation that the assay uses: 107 uL/min
Beside the measured number, compound 3's estimate is 4.3-fold (0.63 log units) below it; the whole stated range lies below it.
By their numbers in this assay, from the lowest: compound 2; then compound 1; then compound 3.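

Placing 3,5-dimethyl-1,2-oxazol-4-yl on this aromatic carbon gave, in this assay, a 6.8-fold higher number from compound 2 to compound 3 (0.83 log units; beyond the scatter) and a 2.8-fold higher number from compound 1 to compound 3 (0.45 log units; beyond the scatter). The earlier compounds carried no aromatic ring at this position, and the first group that does stands above both, so this position can raise the number further than compound 1 had shown. Nothing available bears on why the number rose.

The compounds shown leave open whether this rise follows the aromatic ring itself or its two methyl groups. From the compounds shown here alone, how a phenyl, a pyridine or a carboxylic acid on this carbon would stand also remains open.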